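Swapping Nitro for Trifluoromethyl on a Urea Scaffold

The compounds below may be only part of what the source reports. "The series", "measured", "known", "first", "only" and "open" are said of these compounds alone.

Compound 1 `CCOC(=O)c1ccc(N/C(S)=N/c2ccc3c(c2)C(C)(C)CC(C)(C)O3)cc1` and compound 2 `CCC1(CC)CC(C)(C)c2cc(NC(=O)Nc3ccc([N+](=O)[O-])cc3)ccc2O1` share a common core and were both tested in a functional assay on A2780 cells (Homo sapiens) for inhibition, with a stated time of 72 h; on this read-out lower numbers stand for stronger inhibition and higher numbers for weaker inhibition. In that assay compound 1 gives 4300 nM, while compound 2 gives 2170 nM, so the two numbers lie within the usual scatter of each other and neither can be called the stronger inhibitor. Compound 3 `CCC1(CC)CC(C)(C)c2cc(NC(=O)Nc3ccc(C(F)(F)F)cc3)ccc2O1` has not yet been measured; it differs from compound 2 by trifluoromethyl in place of nitro on an aromatic carbon. For the measured compounds named here, no measured pair here shows how this change acts on the read-out, so no large shift is anticipated. The step of a 1.4-fold higher number from compound 2 to compound 3 (0.14 log units; within the scatter) is expected to stay within the scatter. Compound 3 is therefore estimated at 3000 nM, with a range from 1000 nM to 9000 nM.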

Compound 3, half-maximal inhibitory concentration: 2450 nM
Beside the measured number, compound 3's estimate is 1.2-fold (0.09 log units) above it; the measured number falls inside the stated range.
By their numbers in this assay, from the lowest: compounds 2, 3 and 1 (each within the scatter of the next).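

Trifluoromethyl can take the place of nitro at this position, para to a large group, with no clear change in this assay: the move gives a 1.1-fold higher number from compound 2 to compound 3 (0.05 log units; within the scatter) and stays within the scatter. The 4-nitrophenyl group is therefore not required for this level of inhibition, since 4-(trifluoromethyl)phenyl serves equally well. Nothing available explains why the two groups match. As far as these compounds go, whether an amine or a carboxylic acid at this position would also match remains open. So does the outcome with only a hydrogen there, which would show whether any group is needed.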